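A few compounds are considered here, and "the series" means these few. Any claim that something is new, unique, unknown or untested is made for them only; others in the source may bear on it.

Measured compounds:
compound 1 `CC(C)(C)C1=NN(c2ccc(F)cc2)C(c2ccc(O)cc2)C1`, 9400 nM
compound 2 `CC(C)c1ccc(N2N=C(C(C)(C)C)CC2c2ccc(O)cc2)cc1`, "not determined" (no result reported)

Compound 1 has the structure `CC(C)(C)C1=NN(c2ccc(F)cc2)C(c2ccc(O)cc2)C1`. In an assay on isolated protein for inhibition of protein kinase C zeta type (Homo sapiens), with a stated time of 4 min (on this read-out lower numbers stand for stronger inhibition and higher numbers for weaker inhibition), compound 1 gives 9400 nM. For the measured compounds named here, that is the only number there is: compound 2, with the structure `CC(C)c1ccc(N2N=C(C(C)(C)C)CC2c2ccc(O)cc2)cc1`, was included in the study, but in this assay compound 2 has "not determined" (no result reported), so compound 1 cannot be placed against anything and stands alone.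

Compound 3 has the structure `CC(C)(C)C1=NN(c2cccc(F)c2)C(c2ccc(O)cc2)C1`. It differs from compound 1 by 3-fluorophenyl in place of 4-fluorophenyl on an amine nitrogen in a ring. Since no measured pair shows what a change of this sort does here, there is no basis for expecting a shift in either direction; the step from compound 1 to compound 3 is expected to stay within the usual scatter of repeated measurements, as shown by a 1.0-fold lower number from compound 1 to compound 3 (0.02 log units; within the scatter). Compound 3 is therefore estimated to give 9000 nM in this assay, with a range from 3000 nM to 30000 nM.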

Compound 3, half-maximal inhibitory concentration: 2200 nM
Compound 3: the middle estimate sits 4.1-fold (0.61 log units) above what was measured; the measured number lies below the stated range.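

For the compounds shown here, the first measured pair on this ring nitrogen shows that the place of the fluorine on the phenyl ring matters, even though 3-fluorophenyl and 4-fluorophenyl have the same atoms. In this assay, swapping 4-fluorophenyl for 3-fluorophenyl gives a modest but real gain (a 4.3-fold lower number from compound 1 to compound 3 (0.63 log units; beyond the scatter)), so this part of the molecule responds to a small rearrangement and not only to a change of atoms. Nothing available explains why the shift occurs.

This single pair cannot show whether the gain belongs to fluorine itself or would also appear with another group in the same place, such as 3-chlorophenyl, 3-methoxyphenyl or plain phenyl. It also leaves open whether the same change would have a similar effect on a different core.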